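Replacing the 2-fluorophenyl group of compound 3

The source may hold more compounds than are shown below. What is called first, only, known or untested is meant among the compounds shown, and "the series" means these compounds.

Values measured so far in a functional assay on MCF7 cells (Homo sapiens) for antiproliferative activity, read by MTT assay (a lower number here means a stronger inhibitor, a higher number a weaker inhibitor), are these
compound 1 `COc1cc2c(Oc3ccc(NC(=O)Nc4ccccc4)cc3)ccnc2cc1OCCCCCCC(=O)NO` gives 1040 nM
compound 2 `COc1cc2c(Oc3ccc(NC(=O)Nc4ccc(OC(F)(F)F)cc4)cc3)ccnc2cc1OCCCCCCC(=O)NO` gives 3200 nM
compound 3 `COc1cc2c(Oc3ccc(NC(=O)Nc4ccccc4F)cc3)ccnc2cc1OCCCCCCC(=O)NO` gives 660 nM

Compound 3 cannot be told apart from compound 1 (a 1.6-fold lower number from compound 1 to compound 3 (0.20 log units; within the scatter)), while it stands clear of compound 2 (a 4.8-fold lower number from compound 2 to compound 3 (0.69 log units; beyond the scatter)). The next structure is compound 4 `COc1cc2c(Oc3ccc(NC(=O)N/N=C/c4ccccc4)cc3)ccnc2cc1OCCCCCCC(=O)NO` and the change on the amide-type nitrogen is a group of 8 heavy atoms (7 carbon, 1 nitrogen; one six-membered aromatic ring of carbon only) in place of a group of 7 heavy atoms (6 carbon, 1 fluorine; one six-membered aromatic ring of carbon only), on an amide-type nitrogen with one double bond outside aromatic rings in the entering group.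

The measured steps only alter the aromatic group on that nitrogen, so they offer loose guidance for a change of this kind. The fluoro step stayed small (a 1.6-fold lower number from compound 1 to compound 3 (0.20 log units; within the scatter)) and the trifluoromethoxy step was modest (a 3.1-fold higher number from compound 1 to compound 2 (0.49 log units; beyond the scatter)). On that evidence a modest rise in this assay is the expected outcome, though a step within the scatter remains possible. The estimated step is small to modest (a 1.7-fold higher number from compound 3 to compound 4 (0.22 log units; within the scatter)). Compound 4 is expected at 1100 nM with 350 nM to 3500 nM as its estimated range.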

Compound 4, half-maximal inhibitory concentration: 610 nM
Compound 4: the middle estimate sits 1.8-fold (0.26 log units) above what was measured; the measured number falls inside the stated range.
By their numbers in this assay, from the lowest: compounds 4, 3 and 1 (each within the scatter of the next); then compound 2.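

In this assay, the aromatic group on the amide-type nitrogen can be exchanged for a larger entering group with a double bond outside aromatic rings without a readable shift: against the 2-fluorophenyl group the result is a 1.1-fold lower number from compound 3 to compound 4 (0.03 log units; within the scatter), and against the unsubstituted phenyl group it is a 1.7-fold lower number from compound 1 to compound 4 (0.23 log units; within the scatter). Only the comparison with the 4-(trifluoromethoxy)phenyl group lies beyond the scatter, at a 5.2-fold lower number from compound 2 to compound 4 (0.72 log units; beyond the scatter), so compound 2 remains apart from the other three. No supporting data bear on why the entering group gives this result.

Open, from the compounds shown here alone, is whether the double bond of the entering group is needed, as a saturated chain at the same place would test. Also open, going by these compounds, is how the ring of the entering group would respond to a carboxylic acid or a dimethylamino group.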